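Chain shortening and cytotoxicity in HEL cells

The source may hold more compounds than are shown below. What is called first, only, known or untested is meant among the compounds shown, and "the series" means these compounds.

Measured compounds:
compound 1, `CCCCCCCc1cc2cn(COCCO)c(O)nc-2n1`, 119000 nM
compound 2, `CCCCCCCCCCCc1cc2cn(COCCO)c(O)nc-2n1`, 41000 nM
compound 3, `CCCCCCCCC#Cc1cc2cn(COCCO)c(=O)nc2o1`, 42000 nM

In a functional assay on HEL cells (Homo sapiens) (on this read-out higher numbers stand for lower toxicity in this test and lower numbers for higher toxicity in this test), compound 2 gives 41000 nM and compound 1 gives 119000 nM. The change between them, (hydrogen in place of butyl on a saturated chain carbon, seven bonds along the chain from an aromatic carbon), produces a 2.9-fold higher number from compound 2 to compound 1 (0.46 log units; beyond the scatter). Compound 3 carries a different core; the difference between the core of compound 2 and that of compound 3 is not broken down here. Compound 3 gives 42000 nM, close to compound 2 and apart from compound 1.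

Compound 4, `CCCCC#Cc1cc2cn(COCCO)c(=O)nc2o1`, has not been measured. It differs from compound 3 by hydrogen in place of butyl on a saturated chain carbon, four bonds along the chain from a triple-bonded carbon. This is the same kind of change as that from compound 2 to compound 1, though the place differs: there the butyl sat seven bonds along the chain from an aromatic carbon, here it sits four bonds along the chain from a triple-bonded carbon. Among the measured compounds shown here, because a 2.9-fold higher number from compound 2 to compound 1 (0.46 log units; beyond the scatter) raised the number, compound 4 is expected to show a step of about a 2.6-fold higher number from compound 3 to compound 4 (0.42 log units; beyond the scatter), on a different core and with the single earlier step as the only basis. Compound 4 is therefore estimated at 110000 nM, between 50000 nM and 250000 nM.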

Compound 4, half-maximal cytotoxic concentration: > 50000 nM
Compound 4 ended at the assay's limit; the forecaster's own chance of this, stated with the estimate: 20%; the middle value is on the limit's open side.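

In this assay compound 4 gives > 50000 nM, which is a limit of the assay and not a number. Replacing butyl with hydrogen on the core of compound 3 therefore gives an at least 1.1-fold higher number from compound 3 to compound 4 (0.07 log units; that floor lies within the scatter), a reading that fits the higher number seen on the core of compound 1 but cannot by itself confirm that the change carries over, since its floor does not clear the usual scatter. Set beside the earlier step, the result shows no conflict between the two cores and gives no size for the step on the second core: the same change on two cores in this assay, a 2.9-fold higher number (0.46 log units; beyond the scatter) from compound 2 to compound 1 and an at least 1.1-fold higher number (0.07 log units; that floor lies within the scatter) from compound 3 to compound 4; the limit leaves it open whether they differ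

With a single pair on each core, the compounds shown cannot establish a trend with chain length on either core. They also leave open how the same change would read with a longer chain on the core of compound 3, or with an amine or a carboxylic acid at the chain end.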